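The compounds below may be only part of what the source reports. "The series", "measured", "known", "first", "only" and "open" are said of these compounds alone.

Among the three compounds measured so far in an assay for inhibition of Rho-associated protein kinase 1 (Homo sapiens), read by TR-FRET, with stated times of 5 min and 2 h (on this read-out lower numbers stand for stronger inhibition and higher numbers for weaker inhibition), compound 3, with the structure `CCC1(C)NC(=O)c2sc(-c3ccncc3)cc2N1`, stands lowest: compound 3 gives 36 nM. Compound 1, with the structure `CC1(C)NC(=O)c2sc(-c3ccncc3)cc2N1`, gives 90 nM in this assay, and compound 2, with the structure `CC1(C)NC(=O)c2cc(-c3ccncc3)sc2N1`, gives 100 nM. Going by the values given here, only one measured step bears on what follows: a 2.5-fold lower number from compound 1 to compound 3 (0.40 log units; beyond the scatter), where compound 1 and compound 3 differ in a single carbon on the saturated chain attached to the shared core. Compound 4, with the structure `CC(C)C1(C)NC(=O)c2sc(-c3ccncc3)cc2N1`, carries that idea one bond further out: methyl in place of hydrogen on a saturated chain carbon bound to a saturated chain carbon and a saturated ring carbon, so that the ethyl of compound 3 becomes an isopropyl. Among the compounds with values here, no measured pair shows a second methyl added to this chain, so the single modest step from compound 1 to compound 3 is the only guide, and there is no basis to assume that a second carbon repeats the gain in full. The expectation for the step of a 1.3-fold lower number from compound 3 to compound 4 (0.11 log units; within the scatter) is therefore a small lowering of the number, or none beyond the scatter. Because a 2.5-fold lower number from compound 1 to compound 3 (0.40 log units; beyond the scatter) was modest, compound 4 is expected to give about 28 nM in this assay, with a likely range from 12 nM to 70 nM.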

Compound 4, half-maximal inhibitory concentration: 35 nM
The estimate for compound 4 lay 1.3-fold (0.10 log units) below the measured number, and the stated range covers the measured number.
By their numbers in this assay, from the lowest: compounds 4 and 3 (each within the scatter of the next); then compounds 1 and 2 (each within the scatter of the next).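

In this assay, the step from ethyl to isopropyl, a 1.0-fold lower number from compound 3 to compound 4 (0.01 log units; within the scatter), stays within the scatter, so at this saturated ring carbon a further methyl on the chain brings no change that can be told apart from repeat-measurement noise. Measured from the methyl of compound 1, the isopropyl gives a 2.6-fold lower number from compound 1 to compound 4 (0.41 log units; beyond the scatter), which reads almost the same as a 2.5-fold lower number from compound 1 to compound 3 (0.40 log units; beyond the scatter), so the gain that appeared with ethyl is kept with isopropyl but not extended, and the added branch costs nothing measurable. No measurement at hand explains why the step to ethyl moves the number while the step on to isopropyl does not.

The compounds shown do not tell whether this flat stretch continues with a larger group such as tert-butyl or cyclopropyl, or with a longer chain such as n-propyl, or whether a chain ending in an amine or a hydroxyl group would behave differently. They also leave open whether ethyl or isopropyl would give a similar step on the core of compound 2.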